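Aryl amide variation on the conjugated tetraene series

The source may hold more compounds than are shown below. What is called first, only, known or untested is meant among the compounds shown, and "the series" means these compounds.

Compound 1 `CC1=C(/C=C/C(C)=C/C=C/C(C)=C\C(=O)Nc2ccc(F)cc2)C(C)(C)CCC1n1ccnc1` carries a 4-fluorophenyl amide on the shared core. Going by the values given here, in a functional assay on LNCaP cells (Homo sapiens) for inhibition, read by MTT assay (on this read-out lower numbers stand for stronger inhibition of growth and higher numbers for weaker inhibition of growth), compound 1 gives 3890 nM, the highest of the three numbers so far, though every gap to the others sits within the scatter. Compound 2 `CC1=C(/C=C/C(C)=C/C=C/C(C)=C\C(=O)Nc2ccccc2)C(C)(C)CCC1n1ccnc1` gives 2690 nM, and compound 3 `CC1=C(/C=C/C(C)=C/C=C/C(C)=C\C(=O)Nc2ccccc2O)C(C)(C)CCC1n1ccnc1` gives 3230 nM.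

Compound 4 `CC1=C(/C=C/C(C)=C/C=C/C(C)=C\C(=O)Nc2ccc(O)cc2)C(C)(C)CCC1n1ccnc1` differs from compound 1 as follows: hydroxy in place of fluoro on an aromatic carbon. The change lands on the same aromatic carbon as the step of a 1.4-fold lower number from compound 1 to compound 2 (0.16 log units; within the scatter), and the entering hydroxy is the group that appears in the step of a 1.2-fold higher number from compound 2 to compound 3 (0.08 log units; within the scatter); the step of a 1.2-fold lower number from compound 1 to compound 3 (0.08 log units; within the scatter) also exchanges the whole aryl group for a hydroxy-bearing one. All three steps stay within the scatter, so no step beyond the scatter is expected in this assay.

Compound 4 is therefore estimated at 3200 nM, within 1500 nM to 7000 nM, which means an expected step of a 1.2-fold lower number from compound 1 to compound 4 (0.08 log units; within the scatter).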

Compound 4, concentration for 50% growth inhibition: 3540 nM
Compound 4: the middle estimate sits 1.1-fold (0.04 log units) below what was measured, within the range that was stated.
By their numbers in this assay, from the lowest: compounds 2, 3, 4 and 1 (each within the scatter of the next).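

In this assay, hydroxy in place of fluoro on this aromatic carbon, para to a large group, gives a 1.1-fold lower number from compound 1 to compound 4 (0.04 log units; within the scatter), and hydroxy in place of hydrogen on the same carbon gives a 1.3-fold higher number from compound 2 to compound 4 (0.12 log units; within the scatter), so fluoro, hydrogen and hydroxy at this position cannot be told apart. Moving the hydroxy, from the 2-hydroxyphenyl of one amide to the 4-hydroxyphenyl of the other, gives a 1.1-fold higher number from compound 3 to compound 4 (0.04 log units; within the scatter), so the place of the hydroxy on the aryl ring makes no readable difference among these compounds either. Nothing at hand accounts for this insensitivity.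

As far as these compounds go, whether a larger group at this carbon, such as an amine, a carboxylic acid or a methoxy, would move the number beyond the scatter remains open. Also open, from the compounds shown here alone, is whether a longer alkyl chain in place of the whole aryl group on the amide nitrogen would do so.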